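From tert-butoxycarbonyl to 4-amino-6-chloro-1,3,5-triazin-2-yl

This account rests on a few compounds, and the source may have more. Where it says the series, first, only, none or still open, it means among the compounds named here.

In a toxicity assay on KB cells (Homo sapiens) for cytotoxicity, read by fluorescence, with a stated time of 3 days (a lower number here means that less compound is needed, a higher number that more compound is needed for the effect), compound 1 `CCCCOC(=O)CNC(=O)[C@H](CSc1ccc([N+](=O)[O-])cc1[N+](=O)[O-])NC(=O)CC[C@H](NC(=O)OC)C(=O)OCCCC` reaches only an assay limit, > 300 uM. Compound 2 `CCCCOC(=O)CNC(=O)[C@H](CSc1ccc([N+](=O)[O-])cc1[N+](=O)[O-])NC(=O)CC[C@H](NC(=O)OC(C)(C)C)C(=O)OCCCC` gives 70.4 uM, the higher of the two actual numbers, while compound 3 `CCCCOC(=O)CNC(=O)[C@H](CSc1ccc([N+](=O)[O-])cc1[N+](=O)[O-])NC(=O)CC[C@H](NC(=O)CCc1c[nH]c2ccccc12)C(=O)OCCCC` gives 26 uM. Compound 4 `CCCCOC(=O)CNC(=O)[C@H](CSc1ccc([N+](=O)[O-])cc1[N+](=O)[O-])NC(=O)CC[C@H](Nc1nc(N)nc(Cl)n1)C(=O)OCCCC` differs from compound 2 on an amine nitrogen: 4-amino-6-chloro-1,3,5-triazin-2-yl in place of tert-butoxycarbonyl on an amine nitrogen. Two measured steps change the group at this nitrogen: an at least 4.2-fold lower number from compound 1 to compound 2 (0.62 log units; beyond the scatter) and a 2.7-fold lower number from compound 2 to compound 3 (0.43 log units; beyond the scatter). Both lower the number in this assay, but neither introduces the entering ring, so they offer only loose guidance. A small shift to a lower number is therefore expected, probably not beyond the scatter. The expected change is a 1.8-fold lower number from compound 2 to compound 4 (0.25 log units; within the scatter). For compound 4, the estimated value is 40 uM, with an expected range of 12 uM to 130 uM.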

Compound 4, concentration for half-maximal effect: > 300 uM
Compound 4 ended at the assay's limit; the forecaster's own chance of this, stated with the estimate: 12%; at least 7.5-fold (0.87 log units) between middle value and limit.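

Within the data shown here, replacing tert-butoxycarbonyl on this amine nitrogen with 4-amino-6-chloro-1,3,5-triazin-2-yl gives an at least 4.2-fold higher number from compound 2 to compound 4 (0.62 log units; beyond the scatter) in this assay, the first step at this nitrogen to raise the number, so the direction of change here depends on the entering group. Compound 4 stands at a limit of the assay, not at a number: the limit of > 300 uM in this assay, at which 2 of the 4 values shown sit.

The step between compound 1 and compound 4 cannot be read, since both values are limits. On these data alone, whether an acetyl or a benzyl group on this amine nitrogen would sit nearer compound 3 or compound 4 remains open.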